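This account rests on a few compounds, and the source may have more. Where it says the series, first, only, none or still open, it means among the compounds named here.

Measured compounds in an assay on HEK293 cells for positive allosteric modulation of metabotropic glutamate receptor 5 (Homo sapiens), read by FLIPR; on this read-out lower numbers stand for an effect already at smaller amounts and higher numbers for an effect only at larger amounts of compound:
Compound 1 `Cc1cccc(-c2noc(C3CN(C(=O)c4ccccc4F)C3)n2)c1` gives > 10000 nM, which is a limit of the assay.
Compound 2 `O=C(C1CCC(C(F)(F)F)CC1)N1CC(c2nc(-c3cccc(F)c3)no2)C1` gives 680 nM.
Compound 3 `O=C(c1ccccc1F)N1CC(c2nc(-c3cccc(Cl)c3)no2)C1` gives > 10000 nM, which is a limit of the assay.

Compound 3 therefore stands at the limit of this assay, not at a number, and it shares that position with one other of the three values shown, as the limit of > 10000 nM in this assay, at which 2 of the 3 values shown sit, records. For the measured compounds named here, the only single-point step among the measured compounds, a step that the two limits leave unreadable from compound 1 to compound 3, runs between two limits and its size cannot be read. Compound 2, with a different amide group and a different aryl substituent, is the only compound shown with a numerical value, and no single-point step connects it to compound 3.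

Compound 4 `O=C(c1ccc(F)cc1)N1CC(c2nc(-c3cccc(Cl)c3)no2)C1` differs from compound 3 in one place: 4-fluorophenyl in place of 2-fluorophenyl on a carbonyl carbon. Going by the values given here, no measured step bears on this change, so its direction and size cannot be anchored. Given that compound 3 sits at the limit, compound 4 is estimated at 12000 nM, within 2500 nM to 50000 nM, meaning an expected step that the limit leaves unreadable from compound 3 to compound 4.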

Compound 4, half-maximal effective concentration: > 10000 nM
Compound 4 ended at the assay's limit; the forecaster's own chance of this, stated with the estimate: 60%; the middle value does not contradict the limit.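

Compound 3 and compound 4 both end at a limit of the assay rather than at a number, so no step between them can be read: the limit of > 10000 nM in this assay, at which 3 of the 4 values shown sit.

Left open is whether 4-fluorophenyl and 2-fluorophenyl differ at all here, and which single change separates these compounds from the numerical value of compound 2.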